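Adding Phenoxy to a Compound at the Assay Limit

This account rests on a few compounds, and the source may have more. Where it says the series, first, only, none or still open, it means among the compounds named here.

Measured in a functional assay on HeLa cells (Homo sapiens) for cytotoxicity, read by MTT assay, with a stated time of 24 h; on this read-out higher numbers stand for weaker inhibition and lower numbers for stronger inhibition:
Compound 1 `Nc1cccn2cc(Cc3ccccc3)c(=O)nc12`: 112000 nM
Compound 2 `O=c1nc2ccc(Br)cn2cc1Cc1ccccc1`: 152000 nM
Compound 3 `O=c1nc2ccccn2cc1Cc1ccccc1`: > 1000000 nM, a limit and not a number

Compound 3 stands at the limit of > 1000000 nM in this assay, at which 1 of the 3 values shown sits, so its place is known only as a limit. Compound 1 carries amino and compound 2 carries bromo where compound 3 has hydrogen. The two measured steps are an at least 8.9-fold higher number from compound 1 to compound 3 (0.95 log units; beyond the scatter) and an at least 6.5-fold higher number from compound 2 to compound 3 (0.81 log units; beyond the scatter), both beyond the scatter and both only bounds on the true size.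

Compound 4 `O=c1nc2ccccn2cc1Cc1cccc(Oc2ccccc2)c1` has phenoxy in place of hydrogen on an aromatic carbon of a six-membered aromatic ring of carbon only, meta to a large group: phenoxy in place of hydrogen on an aromatic carbon. Neither measured step changes that ring, so they bear on it only indirectly. Still, each replacement of a hydrogen on compound 3 gave a lower number in this assay, and a step of similar size in that direction is expected here. The expected step is an at least 5.0-fold lower number from compound 3 to compound 4 (0.69 log units; beyond the scatter). For compound 4 the estimated value is 200000 nM, with an expected range from 50000 nM to 800000 nM.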

Compound 4, half-maximal inhibitory concentration: > 1000000 nM
Compound 4 ended at the assay's limit (the forecaster's own chance of this, stated with the estimate: 25%); middle value at least 5.0-fold (0.69 log units) from the limit.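

No new step can be read from compound 3 to compound 4, as each ends at a limit and not a number in this assay: the limit of > 1000000 nM in this assay, at which 2 of the 4 values shown sit.

The compounds shown leave open whether phenoxy in place of hydrogen on an aromatic carbon shifts the number in either direction.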